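The compounds below may be only part of what the source reports. "The series", "measured", "known", "first", "only" and "open" are said of these compounds alone.

Of the compounds shown here, two sharing the same core have been tested so far in a functional assay on the whole organism (Tail, strain ICR) with Mus musculus as the target, in the tail flick test, with a stated time of 30 min, at a dose of 25 umol/kg by the oral route; a higher number here means a stronger effect of the compound at the dose given, a lower number a weaker effect. Compound 1, `O=C(CN(c1nc(Cl)nc2[nH]cnc12)C1CC1)N[C@@H](CC(=O)OCc1ccccc1)C(=O)OCc1ccccc1`, gives 34.7% in this assay, and compound 2, `NC(=O)CC[C@H](NC(=O)CN(c1nc(Cl)nc2[nH]cnc12)C1CC1)C(=O)OCc1ccccc1`, gives 30.8%. The single structural difference between them, a number 3.9 percentage points lower from compound 1 to compound 2 (within the scatter), leaves the two values within the usual scatter of each other, so compound 2 stands beside compound 1 rather than apart from it.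

Compound 3, `O=C(CN(c1nc(Cl)nc2[nH]cnc12)C1CC1)N[C@@H](CO)C(=O)OCc1ccccc1`, has not yet been measured. It differs from compound 2 in one place: hydroxy in place of carbamoylmethyl on a saturated chain carbon, two bonds along the chain from an amide-type nitrogen and a carbonyl carbon. Among the compounds with values here, the only measured step touching this same carbon is the one from compound 1 to compound 2, and that exchange did not move the read-out beyond the scatter. On that basis compound 3 is expected to show no step beyond the scatter either, estimated as a number 0.8 percentage points lower from compound 2 to compound 3 (within the scatter). Compound 3 is therefore estimated at 30%, with a range from 12% to 48%.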

Compound 3, a percentage reported as activity, at one dose (the size of the read-out at that dose, not a potency): 31.9%
Compound 3: middle estimate off by 1.9 percentage points, on the low side, within the range that was stated.
By their numbers in this assay, from the lowest: compounds 2, 3 and 1 (each within the scatter of the next).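

In this assay, putting hydroxy on this saturated chain carbon gives a number 1.1 percentage points higher from compound 2 to compound 3 (within the scatter), and the same group in place of benzyloxycarbonyl gives a number 2.8 percentage points lower from compound 1 to compound 3 (within the scatter). Three different groups have now been compared at this carbon, and they cannot be told apart by this read-out, even though hydroxy is a single oxygen atom while the carbamoylmethyl it replaces has 4 heavy atoms, including a double bond outside any ring. No measurement is available that explains this result.

From the compounds shown here alone, it remains open whether a free carboxylic acid, an amine or a longer carbon chain on this carbon would produce a step beyond the scatter. Going by these compounds, it is also open whether the same insensitivity would hold if the shared core were changed.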